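Methoxy in place of fluoro on compound 3

The compounds below may be only part of what the source reports. "The series", "measured", "known", "first", "only" and "open" are said of these compounds alone.

Compound 1, `COc1ccc(Nc2nc3ccccc3cc2-c2ccc(C)cc2)cc1`, gives 75000 nM in a functional assay on K562 cells (Homo sapiens) for cytotoxicity, read by MTT assay, with a stated time of 72 h; on this read-out lower numbers stand for stronger inhibition and higher numbers for weaker inhibition.
Compound 2, `Cc1ccc(-c2ccnc(Nc3ccc(F)cc3)c2)cc1`, gives 54000 nM.
Compound 3, `Fc1ccc(Nc2ccc3ccccc3n2)cc1`, gives 36000 nM.

Compound 3 has the lowest of the three numbers, but compound 2 sits within the scatter of it, while compound 1 lies beyond the scatter. Compound 4, `COc1ccc(Nc2ccc3ccccc3n2)cc1`, differs from compound 3 by methoxy in place of fluoro on an aromatic carbon. Within the data shown here, no measured pair shows this same change on the core shared by compound 3. Compound 1 carries a methoxy and has the highest number, but it differs from compound 3 in more than one place, so only its value can be noted. The estimated step from compound 3 to compound 4 is a 1.4-fold higher number from compound 3 to compound 4 (0.14 log units; within the scatter), a small rise not clearly beyond the scatter. Compound 4 is therefore expected near 50000 nM, within 20000 nM to 120000 nM.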

Compound 4, half-maximal inhibitory concentration: 30000 nM
Estimate against measurement, compound 4: 1.7-fold (0.22 log units) above, and the stated range covers the measured number.
By their numbers in this assay, from the lowest: compounds 4, 3, 2 and 1 (each within the scatter of the next, the first and the last beyond it).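

In this assay, methoxy in place of fluoro on this aromatic carbon gives a 1.2-fold lower number from compound 3 to compound 4 (0.08 log units; within the scatter), so the two groups cannot be told apart at this position on the shared core. Hydrogen in place of 4-methylphenyl gives a 2.5-fold lower number from compound 1 to compound 4 (0.40 log units; beyond the scatter), the first single-place change here to lie beyond the scatter, though only modestly. No available evidence bears on either step. As far as these compounds go, it remains open whether an amine or a carboxylic acid at this position would shift the number beyond the scatter. Whether fluoro and methoxy also stay level on the core of compound 1 is likewise unresolved.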